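A few compounds are considered here, and "the series" means these few. Any claim that something is new, unique, unknown or untested is made for them only; others in the source may bear on it.

In a functional assay on HL-60 cells (Homo sapiens) for cytotoxicity, read by MTT assay, with a stated time of 46 h (a higher number here means a weaker inhibitor, a lower number a stronger inhibitor), compound 1 `O=C1/C(=C\c2ccncc2)C(c2ccccc2)Oc2ccccc21` gives 1100 nM and compound 2 `Cc1ccc(/C=C2\C(=O)c3ccccc3OC2c2ccccc2)cc1` gives 40800 nM as the higher of the two numbers. Compound 3 `O=C1/C(=C\c2ccc(Cl)cc2)C(c2ccccc2)Oc2ccccc21` differs from compound 2 by chloro in place of methyl on an aromatic carbon with chloro in place of methyl on an aromatic carbon, para to a large group. Going by the values given here, the one measured step is a 37-fold higher number from compound 1 to compound 2 (1.57 log units; beyond the scatter) and it is large, but it put 4-methylphenyl in place of pyridin-4-yl, which is a different change and only a loose guide here. No step beyond the scatter is therefore expected in this assay and the estimated change is a 1.6-fold lower number from compound 2 to compound 3 (0.21 log units; within the scatter) at most a slight drop. For compound 3 the estimated value is 25000 nM with an expected range from 7000 nM to 70000 nM in this assay's terms.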

Compound 3, half-maximal inhibitory concentration: > 1000000 nM
Compound 3: only a limit was reported; the forecaster's own chance of this, stated with the estimate: 15%; at least 40-fold (1.60 log units) between middle value and limit.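

In this assay, compound 3 carries only a limit, not a number: the limit of > 1000000 nM in this assay, at which 1 of the 3 values shown sits. Even so, chloro in place of methyl, one heavy atom for another on an aromatic carbon para to a large group, gives an at least 24-fold higher number from compound 2 to compound 3 (1.38 log units; beyond the scatter), so a swap this small at this position can move the result far beyond the scatter. Pyridin-4-yl replaced by 4-chlorophenyl gives an at least 900-fold higher number from compound 1 to compound 3 (2.95 log units; beyond the scatter).

From the compounds shown here alone, how far the number for compound 3 lies past its limit stays open. So does whether other groups at this place, such as an amine or a methoxy group, would track chloro or methyl.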